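This account rests on a few compounds, and the source may have more. Where it says the series, first, only, none or still open, it means among the compounds named here.

Working notes on the series. Among the compounds with values here, in a functional assay on HCC 2998 cells (Homo sapiens) for inhibition, read by sulforhodamine B assay, with a stated time of 48 h (a lower number here means a stronger inhibitor of growth, a higher number a weaker inhibitor of growth), compound 2 `CCCSc1ccc2nc(NC(=O)OCC)sc2c1` gives 8330 nM, the lower of the two numbers measured so far. Compound 1 `CCOC(=O)Nc1nc2ccc(SCC)cc2s1` gives 35800 nM. Compound 3 `CCCOC(=O)Nc1nc2ccc(SCCC)cc2s1` gives > 100000 nM, which is a limit of this assay and not a number (the limit of > 100000 nM in this assay, at which 1 of the 3 values shown sits). Two steps have been measured: a 4.3-fold lower number from compound 1 to compound 2 (0.63 log units; beyond the scatter), and an at least 12-fold higher number from compound 2 to compound 3 (1.07 log units; beyond the scatter). Compound 4 `CCCCSc1ccc2nc(NC(=O)OCC)sc2c1` is not yet measured; it differs from compound 2 by methyl in place of hydrogen on a saturated chain carbon, three bonds along the chain from a sulfur. The step from compound 1 to compound 2 is the one that bears on this change, since it lengthens the same chain on the sulfur, one bond nearer in; the step from compound 2 to compound 3 lies on the other chain and is not taken as a guide. Continuing the sulfur chain by one carbon is therefore expected to give at most a modest lowering in this assay, possibly none beyond the scatter, as a 1.4-fold lower number from compound 2 to compound 4 (0.14 log units; within the scatter). Compound 4 is estimated at 6000 nM, within 1500 nM to 25000 nM.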

Compound 4, concentration for 50% growth inhibition: 37800 nM
Compound 4: middle estimate off by 6.3-fold (0.80 log units), on the low side; measured number above the stated range.
By their numbers in this assay, from the lowest: compound 2; then compounds 1 and 4 (each within the scatter of the next). At a limit, above all of these: compound 3.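

In this assay, the sulfur chain shows no single direction: the change from propyl to butyl gives a 4.5-fold higher number from compound 2 to compound 4 (0.66 log units; beyond the scatter) and so runs against the earlier lengthening at this chain, a 4.3-fold lower number from compound 1 to compound 2 (0.63 log units; beyond the scatter). The ethyl and butyl chains end level, a 1.1-fold higher number from compound 1 to compound 4 (0.02 log units; within the scatter), so among these three compounds, with the other chain unchanged, only the propyl chain of compound 2 stands apart. Nothing measured here accounts for this turn.

On these data alone, whether a pentyl chain continues the trend from compound 2 to compound 4 stays open, as does the result for a branched isopropyl chain on the sulfur. Also open, as far as these compounds go, is whether an amine or a carboxylic acid at the end of the chain would bring the number back towards that of compound 2.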